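The compounds below may be only part of what the source reports. "The series", "measured", "known", "first", "only" and "open" are said of these compounds alone.

Compound 1 `O=C(Nc1ccc(Br)cc1CN1C(=O)c2ccccc2C1=O)c1ccccn1`: 740 nM
Compound 2 `O=C(Nc1cc(-c2ccccc2)nn1-c1ccccc1)c1ccc(F)c(F)c1`: 10 nM

In an assay on CHO cells with metabotropic glutamate receptor 5 (Homo sapiens) as the target (a lower number here means that less compound is needed, a higher number that more compound is needed for the effect), compound 2 has the lower of the two measured numbers; compound 1 sits far higher, well beyond the usual scatter. Compound 3 `O=C(Nc1cc(-c2ccccc2)nn1-c1ccccc1)c1ccc(F)cc1` has not yet been measured. It differs from compound 2 by hydrogen in place of fluoro on an aromatic carbon. Among the compounds with values here, no pair of measured compounds shows a single small change of this kind, so the data give no direct guide. A modest rise in the number in this assay is expected, and the expected step is a 2.5-fold higher number from compound 2 to compound 3 (0.40 log units; beyond the scatter). Compound 3 is estimated at 25 nM, within 8 nM to 80 nM.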

Compound 3, half-maximal effective concentration: 30 nM
Compound 3: the middle estimate sits 1.2-fold (0.08 log units) below what was measured; the range from low to high includes it.
By their numbers in this assay, from the lowest: compound 2; then compound 3; then compound 1.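

In this assay, the change from 3,4-difluorophenyl to 4-fluorophenyl brings a 3.0-fold higher number from compound 2 to compound 3 (0.48 log units; beyond the scatter) and so lies beyond the usual scatter. Within the data shown here, this is the first pair here that differs in one place only, and it shows that this one fluoro on the aromatic carbon matters on its own, though the step is modest. Nothing available here accounts for the size of this step.

The compounds shown leave open what a chloro, a methoxy or an amine would do at this same carbon. They also leave open whether removing the remaining fluoro, to give a plain phenyl, would raise the number further.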